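The source may report more compounds than this note shows. Statements on the series, on what has been measured and on what is new or still open speak of the compounds shown alone.

Measured so far in a functional assay on PC-3 cells (Homo sapiens) for cytotoxicity, read by MTT assay, with a stated time of 48 h; a lower number here means a stronger inhibitor, a higher number a weaker inhibitor:
Compound 1 `COc1cc(-c2nnc3n2NC(c2ccco2)C(C(=O)c2cccc(Br)c2)S3)cc(OC)c1OC` gives 63900 nM.
Compound 2 `COc1cc(-c2nnc3n2NC(c2ccco2)C(C(=O)c2ccccc2F)S3)cc(OC)c1OC` gives > 100000 nM, a limit of the assay, not a number.
Compound 3 `COc1cc(-c2nnc3n2NC(c2ccco2)C(C(=O)c2ccc(Br)cc2)S3)cc(OC)c1OC` gives 36400 nM.

Compound 1 holds the higher of the two numbers in this assay; its nearest neighbour is compound 3, with a 1.8-fold lower number from compound 1 to compound 3 (0.24 log units; within the scatter). Compound 2 sits at the limit of > 100000 nM in this assay, at which 1 of the 3 values shown sits. Compound 4 `COc1cc(-c2nnc3n2NC(c2ccco2)C(C(=O)c2ccc([N+](=O)[O-])cc2)S3)cc(OC)c1OC` is still to be measured; it differs from compound 1 by 4-nitrophenyl in place of 3-bromophenyl on a carbonyl carbon. For the measured compounds named here, the one comparable step, 4-bromophenyl in place of 3-bromophenyl, gave a 1.8-fold lower number from compound 1 to compound 3 (0.24 log units; within the scatter); the larger change an at least 2.7-fold lower number from compound 2 to compound 3 (0.43 log units; beyond the scatter) involves the 2-fluorophenyl limit. Going by the values given here, no measured step covers bromine giving way to nitro on this ring. Compound 4 is therefore expected to land near compound 3, with a 1.6-fold lower number from compound 1 to compound 4 (0.20 log units; within the scatter), inside the scatter, estimated at 40000 nM within 15000 nM to 100000 nM.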

Compound 4, half-maximal inhibitory concentration: 27900 nM
Beside the measured number, compound 4's estimate is 1.4-fold (0.16 log units) above it, within the range that was stated.
By their numbers in this assay, from the lowest: compounds 4, 3 and 1 (each within the scatter of the next, the first and the last beyond it). At a limit, above all of these: compound 2.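

In (this assay), nitro can stand in place of bromo on the aryl group on the carbonyl carbon without a readable change (a 1.3-fold lower number from compound 3 to compound 4 (0.12 log units; within the scatter)), so this position does not depend on a halogen. Against 3-bromophenyl, 4-nitrophenyl gives a step beyond the scatter (a 2.3-fold lower number from compound 1 to compound 4 (0.36 log units; beyond the scatter)), whereas 4-bromophenyl stayed within it. Against the 2-fluorophenyl limit, only a floor can be read (an at least 3.5-fold lower number from compound 2 to compound 4 (0.55 log units; beyond the scatter)).

Whether an amine or a carboxylic acid at this place would move the number beyond the scatter of these compounds remains open. So does the effect of moving nitro to the 3-position of the phenyl ring.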